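A few compounds are considered here, and "the series" means these few. Any claim that something is new, unique, unknown or untested is made for them only; others in the source may bear on it.

Measured in an ADME assay on S9 fraction from liver (Rattus norvegicus) for metabolic stability, read by LC-MS, using NADPH, with a stated time of 30 min; a higher number here means that more of the compound is left, a lower number that less of the compound is left:
- compound 1 `CCCCCCCCc1ccc(OCC(=O)Cn2nnc(-c3cccc(C(=O)OC)c3)n2)cc1`: 19%
- compound 2 `CCCCCCCCc1ccc(OCC(=O)Cn2nnc(CCC(=O)O)n2)cc1`: < 5%

Compound 2 stands at < 5%, which is a limit and not a number. Compound 3 `CCCCCCCCc1ccc(OCC(=O)Cn2nnc(-c3ccc(C(=O)O)cc3)n2)cc1` has 4-carboxyphenyl in place of 2-carboxyethyl on an aromatic carbon. Within the data shown here, the one measured step that bears on this shows a number at least 14 percentage points lower from compound 1 to compound 2 (beyond the scatter), with 2-carboxyethyl in place of 3-(methoxycarbonyl)phenyl. From the compounds shown here alone, its full size stays open because of the limit of < 5% in this assay, at which 1 of the 2 values shown sits. Compound 1, at 19%, also holds a phenyl group at this place, so a modest rise is expected. The expected step is a number at least 7 percentage points higher from compound 2 to compound 3 (that floor lies within the scatter). For compound 3 the estimate is 12%, with an expected range from 4% to 30%.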

Compound 3, percent of the compound remaining: < 5%
Compound 3 was reported as a limit; the forecaster's own chance of this, stated with the estimate: 30%; middle value at least 7 percentage points away from the limit.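

In this assay compound 3 gives < 5%, which is a limit of the assay. With 4-carboxyphenyl in place of 3-(methoxycarbonyl)phenyl the data show a number at least 14 percentage points lower from compound 1 to compound 3 (beyond the scatter), so a phenyl group at this place does not by itself hold the level of compound 1. The step from compound 2 to compound 3 cannot be read because both values are limits: the limit of < 5% in this assay, at which 2 of the 3 values shown sit.

The compounds shown leave open how a 3-carboxyphenyl group or a methyl ester on the 4-position phenyl group would compare with compound 1. They therefore do not settle whether the carboxylic acid itself goes with the step.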